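Adding a Chlorine to the Urea Aryl of Compound 1

The compounds below may be only part of what the source reports. "The series", "measured", "known", "first", "only" and "open" are said of these compounds alone.

The measured compounds:
compound 1, `O=C(Nc1cccc(-n2cc(-c3ccncc3)c(-c3ccc(Cl)c(O)c3)n2)c1)Nc1cccc(C(F)(F)F)c1`, 3830 nM
compound 2, `COc1cc(-c2nn(-c3cccc(NC(=O)Nc4cccc(C(F)(F)F)c4)c3)cc2-c2ccncc2)ccc1Cl`, 1230 nM
compound 3, `COc1cc(-c2nn(-c3cccc(NC(=O)c4ccccc4)c3)cc2-c2ccncc2)ccc1Cl`, 551 nM

In a functional assay on SW-620 cells (Homo sapiens) for inhibition, read by sulforhodamine B assay, with a stated time of 48 h (a lower number here means a stronger inhibitor of growth, a higher number a weaker inhibitor of growth), compound 1 gives 3830 nM, the highest of the three numbers. Its nearest neighbour is compound 2, reached by the step of a 3.1-fold lower number from compound 1 to compound 2 (0.49 log units; beyond the scatter). Compound 3 lies further away still, with the step of a 2.2-fold lower number from compound 2 to compound 3 (0.35 log units; beyond the scatter) separating it from compound 2.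

Compound 4, `O=C(Nc1cccc(-n2cc(-c3ccncc3)c(-c3ccc(Cl)c(O)c3)n2)c1)Nc1ccc(Cl)c(C(F)(F)F)c1`, is the next step from compound 1. The change is chloro in place of hydrogen on an aromatic carbon, placed on an aromatic carbon ortho to a trifluoromethyl group and para to a large group. Neither measured step touches this ring: one alters the oxygen substituent, the other replaces the whole urea with a benzamide. Among the measured compounds shown here, no measured step therefore bears directly on this change. The account thus expects, without evidence either way, only a small step in this assay, perhaps a slightly lower number, and estimates for compound 4 a value of 2500 nM (range 900 nM to 7000 nM), meaning the expected step of a 1.5-fold lower number from compound 1 to compound 4 (0.19 log units; within the scatter).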

Compound 4, concentration for 50% growth inhibition: 1150 nM
Estimate against measurement, compound 4: 2.2-fold (0.34 log units) above, and the stated range covers the measured number.
By their numbers in this assay, from the lowest: compound 3; then compounds 4 and 2 (each within the scatter of the next); then compound 1.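

In this assay, the ring bearing the trifluoromethyl group proves responsive to a single added atom: chloro in place of hydrogen, on the aromatic carbon ortho to that group and para to a large group, gives a 3.3-fold lower number from compound 1 to compound 4 (0.52 log units; beyond the scatter) and lies beyond the scatter. Among the compounds shown here, the earlier steps altered the oxygen substituent or replaced the whole urea, so this is the first step to show that this ring can change the number while the rest of compound 1 stays the same. No evidence is available to explain this step.

Going by these compounds, whether another group at this carbon, such as fluoro, methyl or an amine, would give a similar step remains open. Also open, on these data alone, is whether chloro here would lower the number further in compound 2, which carries a methyl on the oxygen.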